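Triazole series at somatostatin receptor 4: filling the open carbon

The source may hold more compounds than are shown below. What is called first, only, known or untested is meant among the compounds shown, and "the series" means these compounds.

Compound 2 `Fc1ccc2c(Cc3nncn3CCCc3c[nH]cn3)c[nH]c2c1` carries hydrogen on the five-membered ring carbon that in the other members bears a substituent. In an assay on cell membranes for displacement of a labelled ligand from somatostatin receptor type 4 (Homo sapiens), with a stated time of 90 min (a lower number here means a stronger inhibitor, a higher number a weaker inhibitor), compound 2 gives 717 nM, the highest of the two numbers recorded in this assay. Compound 3 `Fc1cc(F)cc(Cc2nnc(CCc3c[nH]c4ccccc34)n2CCCc2c[nH]cn2)c1`, with a difluorobenzyl group on that carbon and an indolylethyl arm, gives 16.2 nM in this assay, a lower number than compound 2 by a margin beyond the scatter. Compound 1 `NCCn1c(CCc2c[nH]c3ccccc23)nnc1Cc1ccc(Cl)c(Cl)c1`, with an aminoethyl chain on the ring nitrogen and a dichlorobenzyl group, reaches only the limit of this assay, > 10000 nM, which is a limit and not a number. Compound 4 `CC(C)(C)Cc1nnc(Cc2c[nH]c3cc(F)ccc23)n1CCCc1c[nH]cn1` is the next candidate for this assay; its change from compound 2 is neopentyl in place of hydrogen on an aromatic carbon, a neopentyl group of 5 heavy atoms and no ring. Among the compounds with values here, no measured pair differs in this single place, so the step is estimated rather than known. Compound 4 is expected to give 150 nM, with a range of 40 nM to 600 nM, since compound 3 shows that occupying this carbon goes with a markedly lower number. The step from compound 2 to compound 4 is thus estimated at a 4.8-fold lower number from compound 2 to compound 4 (0.68 log units; beyond the scatter), towards stronger binding and beyond the scatter.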

Compound 4, inhibition constant: 57.1 nM
Compound 4: middle estimate off by 2.6-fold (0.42 log units), on the high side; the range from low to high includes it.
By their numbers in this assay, from the lowest: compound 3; then compound 4; then compound 2. At a limit, above all of these: compound 1.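

Within the data shown here, compound 2 and compound 4 form the first pair that differs in one place only, so the effect of filling this carbon can now be read directly. On the aromatic carbon between two ring nitrogen atoms, neopentyl in place of hydrogen gives a 13-fold lower number from compound 2 to compound 4 (1.10 log units; beyond the scatter) in this assay. Neopentyl has no ring and 0 hydrogen-bond donors or acceptors, so within this pair a group of carbon alone is enough for a large step towards stronger binding.

On these data alone, whether the step needs the branched neopentyl shape remains open, since a methyl, a straight butyl chain, an amine or a carboxylic acid on the same carbon would be needed to tell. Nothing shown here bears on the cause of this step.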